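The compounds below may be only part of what the source reports. "The series", "measured", "known", "first", "only" and "open" are said of these compounds alone.

In a physicochemical assay for lipophilicity (on this read-out higher numbers stand for higher lipophilicity and lower numbers for lower lipophilicity), compound 1 (`CCn1ncc(-c2nc3c(O[C@H]4CCN(C(=O)C5CCOCC5)C4)ncnc3n2C)c1C`) gives 1.1 as its result, and compound 2 (`CCC(=O)N1CC[C@H](Nc2ncnc3c2nc(-c2cnn(CC)c2C)n3C)C1`) gives 0.8 as its result. These two numbers lie within the usual scatter of each other, so they cannot be told apart. Compound 2 therefore offers a starting point with no clear rank of its own.

The next compound, compound 3 (`CCn1ncc(-c2nc3c(N[C@H]4CCN(C(=O)C5CCOCC5)C4)ncnc3n2C)c1C`), comes from compound 2 by one change on a carbonyl carbon whose other neighbours are an amide-type nitrogen in a ring. Here oxan-4-yl in place of ethyl on a carbonyl carbon is the whole difference, with oxan-4-yl in place of ethyl. Cut one bond further out, the same difference reads propanoyl to (oxan-4-yl)carbonyl.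

Within the data shown here, no pair of measured compounds differs in one place only, so no measured step shows what this change does on its own in this assay so far. The expectation is therefore a small upward move, or none beyond the scatter. The expected size is a number 0.10 log units higher from compound 2 to compound 3 (within the scatter) on this scale. For compound 3 the estimated value is 0.9 here, with an expected range from 0.5 to 1.3 around it.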

Compound 3, distribution coefficient: 0.8
The estimate for compound 3 lay 0.10 log units above the measured number; low and high end bracket the measured number.
By their numbers in this assay, from the lowest: compounds 2, 3 and 1 (each within the scatter of the next).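

Among these compounds, this is the first measured step that isolates one place. In this assay, oxan-4-yl in place of ethyl on a carbonyl carbon, whose other neighbour is an amide-type nitrogen in a ring, shows no change at the digits printed from compound 2 to compound 3 (within the scatter). The entering group has 6 heavy atoms against 2 for ethyl, and it adds a six-membered non-aromatic ring and 1 hydrogen-bond acceptor, yet this larger group gives a number that cannot be told apart from the ethyl one, so at this position and for this pair, the read-out does not register the exchange. No supporting measurement is available to account for this result.

The compounds shown leave open whether any other group on this carbonyl carbon would move the number beyond the scatter, such as a piperidin-4-yl ring with its ring amine, a chain ending in a carboxylic acid, or a longer chain such as hexyl. They also leave open whether the same exchange of ethyl for oxan-4-yl would read alike on a different core, since this single step comes from one pair of compounds.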